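Terminal double bond on the octyl chain: expected cytotoxicity

The source may hold more compounds than are shown below. What is called first, only, known or untested is meant among the compounds shown, and "the series" means these compounds.

Measured so far:
compound 1 `CCCCCCCCc1cc2cn([C@H]3C[C@H](O)[C@@H](CO)O3)c(=O)nc2o1` — > 50000 nM
compound 2 `CCCCCCCCCCc1cc2cn([C@H]3C[C@H](O)[C@@H](CO)O3)c(=O)nc2o1` — > 50000 nM
compound 3 `C=CCCCc1cc2cn([C@H]3C[C@H](O)[C@@H](CO)O3)c(=O)nc2o1` — > 200000 nM

In a functional assay on HEL cells (Homo sapiens) for cytotoxicity (on this read-out higher numbers stand for lower toxicity in this test and lower numbers for higher toxicity in this test), compound 1 gives > 50000 nM, which is a limit of the assay and not a number. Compound 4 `C=CCCCCCCc1cc2cn([C@H]3C[C@H](O)[C@@H](CO)O3)c(=O)nc2o1` differs from compound 1 by vinyl in place of ethyl on a saturated chain carbon, six bonds along the chain from an aromatic carbon; the chain keeps its length and gains one double bond outside the aromatic rings. The steps a step that the two limits leave unreadable from compound 1 to compound 2, a step that the two limits leave unreadable from compound 1 to compound 3 and a step that the two limits leave unreadable from compound 2 to compound 3 give no readable size, since the values sit at the limit of > 50000 nM in this assay, at which 2 of the 3 values shown sit, and at the limit of > 200000 nM in this assay, at which 1 of the 3 values shown sits. Nothing among these compounds therefore points to a step beyond the scatter, and the expected step of a number no higher from compound 1 to compound 4 (the limit leaves the size open) is essentially none. Compound 4 is expected to give 50000 nM, with a range from 20000 nM to 200000 nM, most likely again reported only as a limit.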

Compound 4, half-maximal cytotoxic concentration: > 200000 nM
Compound 4: no number, only a limit (the forecaster's own chance of this, stated with the estimate: 90%); middle value at least 4.0-fold (0.60 log units) from the limit.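

In this assay compound 4 gives > 200000 nM, which is a limit and not a number. Its steps against compound 1, compound 2 and compound 3 cannot be read; all four values are limits. From the compounds shown here alone, whether the terminal double bond changes toxicity at all stays open.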